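The source may report more compounds than this note shows. Statements on the series, on what has been measured and on what is new or still open speak of the compounds shown alone.

Of the compounds shown here, two have been measured in an ADME assay on L1210/0 cells (Mus musculus) for cytotoxicity, with a stated time of 48 h; on this read-out lower numbers stand for stronger inhibition and higher numbers for weaker inhibition. Compound 1 `O=C1O/C(=C\Cn2cc(C(F)(F)F)c(=O)[nH]c2=O)C(OCc2ccccc2)=C1OCc1ccccc1` gives 2000 nM in this assay. Compound 2 `O=c1[nH]c(=O)n([C@H]2C[C@H](O)[C@@H](CO)O2)cc1C#CCO` shows only a limit of this assay, > 200000 nM, which is the limit of > 200000 nM in this assay, at which 1 of the 2 values shown sits. Among the numbers shown, compound 2 therefore stands at the weak end. Compound 3 `CCC#Cc1cn([C@H]2C[C@H](O)[C@@H](CO)O2)c(=O)[nH]c1=O` differs from compound 2 in a single place: methyl in place of hydroxy on a saturated chain carbon bound to a triple-bonded carbon. Within the data shown here, no measured step of this kind exists here. The step expected from compound 2 to compound 3 an at least 1.3-fold lower number from compound 2 to compound 3 (0.12 log units; that floor lies within the scatter) is expected to be none beyond the scatter. Compound 3 is estimated at 150000 nM, with a range from 40000 nM to 400000 nM.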

Compound 3, half-maximal inhibitory concentration: > 200000 nM
Compound 3: no number, only a limit; the forecaster's own chance of this, stated with the estimate: 60%; middle value at least 1.3-fold (0.12 log units) from the limit.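

Compound 2 and compound 3 both give only a limit in this assay, so no step between them can be read, because both stop at the same point: the limit of > 200000 nM in this assay, at which 2 of the 3 values shown sit.

From the compounds shown here alone, whether methyl in place of hydroxy changes the result at all stays open.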